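The source may report more compounds than this note shows. Statements on the series, on what has been measured and on what is new or still open speak of the compounds shown alone.

The measured compounds so far:
Compound 1, `C[C@@H](O)[C@H]1C(=O)N2C3=C(S[C@@H]4CN[C@@H](C4)C(=O)Nc4cccc(c4)C(=O)OCCCCOC3=O)[C@H](C)[C@H]12`, gives > 95% in an ADME assay for metabolic stability, read by LC-MS, with a stated time of 3 h, at pH 6.5, tested at 50 uM; a higher number here means that more of the compound is left, a lower number that less of the compound is left; this is a limit of the assay rather than a number.
Compound 2, `C[C@@H](O)[C@H]1C(=O)N2C(C(=O)OCc3oc(=O)oc3C(C)(C)C)=C(S[C@@H]3CN[C@H](C(=O)Nc4cccc(C(=O)OCc5oc(=O)oc5C(C)(C)C)c4)C3)[C@H](C)[C@H]12`, gives > 95% in this assay; this too is a limit.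
Compound 3, `CC(C)C(=O)OCOC(=O)C1=C(S[C@@H]2CN[C@H](C(=O)Nc3cccc(C(=O)O)c3)C2)[C@H](C)[C@@H]2[C@@H]([C@@H](C)O)C(=O)N12`, gives > 95% in this assay; again a limit.

Compound 3 therefore stands exactly where the other two stand, at the limit of > 95% in this assay, at which 3 of the 3 values shown sit. Going by the values given here, no number separates any of the three, and no step between two measured compounds can be drawn from them.

Compound 4, `CCC(CC)C(=O)OCOC(=O)C1=C(S[C@@H]2CN[C@H](C(=O)Nc3cccc(C(=O)O)c3)C2)[C@H](C)[C@@H]2[C@@H]([C@@H](C)O)C(=O)N12`, has not yet been measured in this assay. It differs from compound 3 in a single place: pentan-3-yl in place of isopropyl on a carbonyl carbon. The acyl part of the ester grows from isopropylcarbonyl to (pentan-3-yl)carbonyl while the rest of the molecule is kept.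

Because compound 3 sits at the limit of > 95% in this assay, at which 3 of the 3 values shown sit, there is no room upward, and the change is a small one. The step from compound 3 to compound 4 is expected to be a step that the limit leaves unreadable from compound 3 to compound 4, that is, none beyond the usual scatter. Compound 4 is expected to give 96% in this assay, with a range from 88% to 99%, and most likely again only a limit will be reported.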

Compound 4, percent of the compound remaining: > 95%
Compound 4 ended at the assay's limit (the forecaster's own chance of this, stated with the estimate: 80%); the middle value lies beyond the limit too.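

Compound 4 gives > 95% in this assay, which is a limit and not a number. No step from compound 3 to compound 4 can be read, because both stand at the same limit: the limit of > 95% in this assay, at which 4 of the 4 values shown sit.

The compounds shown leave open whether the four differ at all in this assay, and whether any change in the acyl part of the ester would give a readable value.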